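Moving an Ethyl Group Onto the Sulfonamide Aryl Ring

The source may hold more compounds than are shown below. What is called first, only, known or untested is meant among the compounds shown, and "the series" means these compounds.

Compound 1 `O=C1NCCN1c1ccc(S(=O)(=O)Nc2ccc3[nH]ccc3c2)cc1` gives 87 nM
Compound 2 `O=C1NCCN1c1ccc(S(=O)(=O)Nc2ccc(C3CCCCC3)cc2)cc1` gives > 1000 nM (a limit)
Compound 3 `Cc1ccc(NS(=O)(=O)c2ccc(N3CCNC3=O)cc2)cc1C` gives 94 nM

In a functional assay on M21 cells (Homo sapiens) for antiproliferative activity, read by sulforhodamine B assay, with a stated time of 48 h (on this read-out higher numbers stand for weaker inhibition and lower numbers for stronger inhibition), compound 3 (at 94 nM) and compound 1 (at 87 nM) lie within the usual scatter of each other. Compound 2 (entry > 1000 nM) is reported only as a limit of the assay.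

Compound 4 `CCc1cccc(NS(=O)(=O)c2ccc(N3CCNC3=O)cc2)c1` has not yet been measured. It has the same atoms as compound 3, joined differently (3-ethylphenyl in place of 3,4-dimethylphenyl on a sulfonamide nitrogen), with 3-ethylphenyl in place of 3,4-dimethylphenyl on a sulfonamide nitrogen. Among the compounds with values here, no two measured compounds differ in one place only, so the size of this change has not been seen directly. The expectation rests on compound 3 (at 94 nM), which carries the same atoms. The estimated step is small and toward weaker inhibition (a 1.4-fold higher number from compound 3 to compound 4 (0.14 log units; within the scatter)), and it is not expected to go beyond the scatter. The value estimated for compound 4 is 130 nM (expected range 45 nM to 400 nM).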

Compound 4, half-maximal inhibitory concentration: 82 nM
Compound 4: the middle estimate sits 1.6-fold (0.20 log units) above what was measured; the measured number falls inside the stated range.
By their numbers in this assay, from the lowest: compounds 4, 1 and 3 (each within the scatter of the next). At a limit, above all of these: compound 2.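

In this assay, within the data shown here, 3-ethylphenyl in place of 3,4-dimethylphenyl on a sulfonamide nitrogen gives a 1.1-fold lower number from compound 3 to compound 4 (0.06 log units; within the scatter), the only step here between measured compounds that differ in one place. It shows directly that, for this pair, the same atoms can be joined in these two ways at this place without a difference beyond the scatter. Nothing measured here explains why the two compounds read alike.

Still open, on these data alone, is whether an amine, a carboxylic acid or a longer chain on the aryl ring would keep the value of compound 4 at 82 nM. Among these compounds, also open is how the value would respond to a change elsewhere on the shared core, since the only step that can be read lies at this one place.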